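The compounds below may be only part of what the source reports. "The series", "measured", "known", "first", "only" and "open" are said of these compounds alone.

The study concerns a set of nucleoside analogues built on a shared core with a variable group attached, all tested in a functional assay on L1210 cells (Mus musculus); a higher number here means a weaker inhibitor, a lower number a stronger inhibitor. Compound 1, `CCCCCc1cn([C@H]2C[C@H](O)[C@@H](CO)O2)c(=O)[nH]c1=O`, carries a pentyl chain on that core. In this assay, going by the values given here, compound 1 gives 476 ug/mL, the only plain number among the values known so far. Compound 2, `CC(C)c1cn([C@H]2C[C@@H]3OP(=O)(O)OC[C@H]3O2)c(=O)[nH]c1=O`, combines an isopropyl group with a cyclic phosphate. For compound 2 in this assay the result is only a limit, > 500 ug/mL, as recorded in the limit of > 500 ug/mL in this assay, at which 1 of the 2 values shown sits. Among the compounds with values here, no step between two measured compounds is available, so compound 1 is the sole anchor. Compound 3, `CCCc1cn([C@H]2C[C@H](O)[C@@H](CO)O2)c(=O)[nH]c1=O`, differs from compound 1 by hydrogen in place of ethyl on a saturated chain carbon, three bonds along the chain from an aromatic carbon. Compound 1 already sits near the upper edge of what this assay reports. The step of a 1.1-fold higher number from compound 1 to compound 3 (0.02 log units; within the scatter) is therefore expected to be small, with any drift more likely towards weaker than towards stronger inhibition. The estimate for compound 3 in this assay is 500 ug/mL, expected to fall between 250 ug/mL and 1000 ug/mL, with a fair chance that only a limit is reported.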

Compound 3, concentration for 50% inhibition: > 500 ug/mL
Compound 3 ended at the assay's limit; the forecaster's own chance of this, stated with the estimate: 50%; the middle value lies on the limit itself.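

The change from pentyl to propyl on the shared core, hydrogen in place of ethyl on a saturated chain carbon, reads as an at least 1.0-fold higher number from compound 1 to compound 3 (0.02 log units; that floor lies within the scatter), so this step has a floor but no measured size, and that floor says nothing beyond the scatter. In this assay compound 3 gives > 500 ug/mL, which is a limit of the assay and not a number. What this adds for the position is one firm point: removing ethyl from the chain does not bring a read-out towards stronger inhibition, and pentyl remains the only chain shown with a plain number, while the values shown now gather at the assay's limit: the limit of > 500 ug/mL in this assay, at which 2 of the 3 values shown sit.

Going by these compounds, how far propyl actually lies from pentyl stays unknown, since only a floor is available for the step. Also open, on these data alone, is how a longer chain such as heptyl or octyl, or a pentyl chain ending in an amine or a carboxylic acid, would read at this position, and whether any of these would give a plain number on the stronger side.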